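The compounds below may be only part of what the source reports. "The series", "measured", "known", "first", "only" and "open" are said of these compounds alone.

Measured compounds:
compound 1 `Cc1ccccc1S(=O)(=O)Nc1ccc2oc(-c3ccccc3)nc2c1`, > 100000 nM in an assay on cells for inhibition of HSP60/HSP10 (Homo sapiens), with a stated time of 60 min; on this read-out lower numbers stand for stronger inhibition and higher numbers for weaker inhibition
compound 2 `O=S(=O)(Nc1ccc2oc(-c3ccccc3)nc2c1)c1cccc(O)c1`, 76000 nM
compound 3 `O=S(=O)(Nc1ccc2oc(-c3ccccc3)nc2c1)c1ccc(O)cc1`, 88000 nM
Not yet measured: compound 4 `CCc1ccc(S(=O)(=O)Nc2ccc3oc(-c4ccccc4)nc3c2)cc1`

The value of compound 1 is a limit of this assay and not a number (the limit of > 100000 nM in this assay, at which 1 of the 3 values shown sits). Compound 3 holds the higher of the two numbers that are known, but the step of a 1.2-fold higher number from compound 2 to compound 3 (0.06 log units; within the scatter) lies within the scatter, so compound 2 and compound 3 cannot be ordered. The steps of an at least 1.3-fold lower number from compound 1 to compound 2 (0.11 log units; that floor lies within the scatter) and an at least 1.1-fold lower number from compound 1 to compound 3 (0.05 log units; that floor lies within the scatter) both have floors within the scatter and say little.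

Compound 4 differs from compound 3 by ethyl in place of hydroxy on an aromatic carbon. Among the measured compounds shown here, no measured step swaps hydroxy for ethyl. The only alkyl-bearing phenyl in the set, the 2-methylphenyl of compound 1, sits at the limit, whereas the two hydroxyphenyl compounds give numbers; this points to a higher number for compound 4, possibly again a limit. Compound 4 is therefore expected at 120000 nM, with a range from 50000 nM to 300000 nM. The expected step is a 1.4-fold higher number from compound 3 to compound 4 (0.13 log units; within the scatter), i.e. a higher number, with a fair chance that only a limit is reported.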

Compound 4, half-maximal inhibitory concentration: > 100000 nM
Compound 4: no number, only a limit; the forecaster's own chance of this, stated with the estimate: 50%; the middle value does not contradict the limit.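

In this assay compound 4 gives > 100000 nM, a limit of the assay and not a number: the limit of > 100000 nM in this assay, at which 2 of the 4 values shown sit. With ethyl in place of hydroxy, the readable changes are an at least 1.1-fold higher number from compound 3 to compound 4 (0.05 log units; that floor lies within the scatter) and an at least 1.3-fold higher number from compound 2 to compound 4 (0.11 log units; that floor lies within the scatter), so neither shows a real loss on this change, and the step between the two limit compounds, compound 1 and compound 4, cannot be read. What is new is that an alkyl group on the aromatic carbon para to a large group also ends at the limit, so across these four compounds only the hydroxyphenyl compounds, compound 2 and compound 3, give numbers, and none goes against this.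

As far as these compounds go, how far compound 1 and compound 4 lie from compound 2 and compound 3 stays open. Also open, from the compounds shown here alone, is whether an amine or a carboxylic acid on this carbon would give a number, and whether any group here would give a much lower one.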